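Adding a Fluoro Group to Compound 3

The compounds below may be only part of what the source reports. "The series", "measured", "known", "first", "only" and "open" are said of these compounds alone.

Compound 1, `CN(C)CCCCCSC1=Nc2ccccc2C(CC(=O)NCc2ccccc2)N1c1ccc(-c2ccc(F)cc2)cc1`: in an assay on cells for inhibition of Voltage-dependent T-type calcium channel subunit alpha-1H (Homo sapiens), read by patch clamp (on this read-out lower numbers stand for stronger inhibition and higher numbers for weaker inhibition), compound 1 gives 4180 nM.
Compound 2, `CN(C)CCCCCSC1=Nc2ccccc2C(CC(=O)NCc2ccccc2)N1c1ccc(-c2ccccc2)cc1`: compound 2 gives 2400 nM.
Compound 3, `CN(C)CCCCCSC1=Nc2ccccc2C(CC(=O)NCc2ccc(F)cc2)N1c1ccc(-c2ccccc2)cc1`: compound 3 gives 3140 nM.

Compound 3 sits second highest among these three numbers, yet its nearest neighbour is compound 2 and its furthest is compound 1, and both of those gaps lie within the usual scatter, so the three compounds cannot be ranked against one another on this read-out.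

Compound 4, `CN(C)CCCCCSC1=Nc2ccccc2C(CC(=O)NCc2ccc(F)cc2)N1c1ccc(-c2ccc(F)cc2)cc1`, differs from compound 3 by fluoro in place of hydrogen on an aromatic carbon. Cut one bond further out, the change reads as phenyl to 4-fluorophenyl on the biaryl end of the core, so compound 4 carries the fluoro group of compound 1 together with that of compound 3.

Within the data shown here, two measured steps bear on this change. The step of a 1.7-fold lower number from compound 1 to compound 2 (0.24 log units; within the scatter) is the same exchange run backwards, on a core lacking the benzylamide fluoro group. The step of a 1.3-fold higher number from compound 2 to compound 3 (0.12 log units; within the scatter) is the same kind of exchange at the other aromatic ring. Neither left the scatter. The account therefore expects compound 4 to show at most a small rise in this assay, a 1.6-fold higher number from compound 3 to compound 4 (0.20 log units; within the scatter), and estimates compound 4 at 5000 nM, between 2500 nM and 10000 nM.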

Compound 4, half-maximal inhibitory concentration: 2760 nM
Compound 4: the middle estimate sits 1.8-fold (0.26 log units) above what was measured; the measured number falls inside the stated range.
By their numbers in this assay, from the lowest: compounds 2, 4, 3 and 1 (each within the scatter of the next).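

Fluoro in place of hydrogen on the biaryl end, now read with a fluoro group already on the other aromatic ring, gives a 1.1-fold lower number from compound 3 to compound 4 (0.06 log units; within the scatter), and the same exchange on that other ring, read with the biaryl fluoro group in place, gives a 1.5-fold lower number from compound 1 to compound 4 (0.18 log units; within the scatter), so the two fluoro groups together leave the number in this assay within the scatter of each single-fluoro compound. The phenyl to 4-fluorophenyl exchange can now be compared on two cores, and the two readings agree within the scatter: the same change on two cores in this assay, a 1.7-fold lower number (0.24 log units; within the scatter) from compound 1 to compound 2 and a 1.1-fold higher number (0.06 log units; within the scatter) from compound 4 to compound 3, 2.0-fold (0.30 log units) apart, within the scatter of two such steps The exchange on the other aromatic ring can also be compared on two cores, and again no dependence on the core can be told from the numbers: the same change on two cores in this assay, a 1.3-fold higher number (0.12 log units; within the scatter) from compound 2 to compound 3 and a 1.5-fold lower number (0.18 log units; within the scatter) from compound 1 to compound 4, 2.0-fold (0.30 log units) apart, within the scatter of two such steps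

The compounds shown leave open whether a group other than fluoro on either aromatic ring, such as methoxy, trifluoromethyl or an amine, would move the number in this assay beyond the scatter. They also leave open whether a shorter or longer chain leading to the dimethylamino group would change the number, or would change how little these fluoro exchanges matter.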